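The source may hold more compounds than are shown below. What is called first, only, known or untested is meant among the compounds shown, and "the series" means these compounds.

Compound 1 `Cc1cc(I)cc2c(=O)[nH]c(CSc3ccc(C(=O)O)cc3)nc12` is one of two measured members of the series. In an assay for inhibition of protein mono-ADP-ribosyltransferase PARP4 (Homo sapiens), read by chemiluminescence, with stated times of 10 min and 60 min (on this read-out higher numbers stand for weaker inhibition and lower numbers for stronger inhibition), compound 1 gives 800 nM. Compound 2 `Cc1cc(Br)cc2c(=O)[nH]c(CSc3ncccn3)nc12` in this assay gives 800 nM; compound 1 and compound 2 are level within the scatter, so no ordering between them is drawn. Compound 3 `Cc1cc(Br)cc2c(=O)[nH]c(CSc3ccc(C(=O)O)cc3)nc12` is not yet measured. It differs from compound 1 by bromo in place of iodo on an aromatic carbon. Among the measured compounds shown here, no measured step shows what a halogen exchange of this kind does here, so the expected step of no change at the digits printed from compound 1 to compound 3 (within the scatter) is none beyond the scatter. Compound 3 is estimated at 800 nM, with a range from 400 nM to 1600 nM.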

Compound 3, half-maximal inhibitory concentration: 1900 nM
Beside the measured number, compound 3's estimate is 2.4-fold (0.38 log units) below it; measured number outside the range, above it.
By their numbers in this assay, from the lowest: compounds 1 and 2 (each within the scatter of the next); then compound 3.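

In this assay, among the compounds shown here, this aromatic carbon proves sensitive to the identity of its halogen: bromo in place of iodo gives a 2.4-fold higher number from compound 1 to compound 3 (0.38 log units; beyond the scatter) and this is the first measured step at this position. Of this pair, iodo carries the lower number, so the two halogens are not interchangeable here on the core of compound 1. No measured data on these compounds offer an explanation for the step.

A single halogen pair cannot show how chloro, fluoro or an amine on this carbon would read. As far as these compounds go, whether the exchange gives a similar step alongside the side chain of compound 2 also remains open.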